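Swapping the furanyl amide for a 4-ethylbenzyl amide

The source may hold more compounds than are shown below. What is called first, only, known or untested is meant among the compounds shown, and "the series" means these compounds.

Measured compounds:
compound 1, `CN(C(=O)c1cc2c(Cc3ccccc3)n[nH]c2cc1O)c1ccco1`, 2500 nM
compound 2, `CN(Cc1ccccc1F)C(=O)c1cc2c(Cc3ccccc3)n[nH]c2cc1O`, 1500 nM
compound 3, `CN(Cc1cccc(Br)c1)C(=O)c1cc2c(Cc3ccccc3)n[nH]c2cc1O`, 7100 nM

The three compounds share a core and differ only in the group on the amide-type nitrogen. In a functional assay on A2780 cells (Homo sapiens) for antiproliferative activity, read by resazurin assay, with a stated time of 72 h (on this read-out lower numbers stand for stronger inhibition and higher numbers for weaker inhibition), compound 1 stands second highest of the three numbers, with compound 1 giving 2500 nM. Its nearest neighbour is compound 2: a 1.7-fold lower number from compound 1 to compound 2 (0.22 log units; within the scatter). The furthest is compound 3: a 2.8-fold higher number from compound 1 to compound 3 (0.45 log units; beyond the scatter). Between the two benzyl analogues the step is a 4.7-fold higher number from compound 2 to compound 3 (0.68 log units; beyond the scatter).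

The unmeasured compound 4, `CCc1ccc(CN(C)C(=O)c2cc3c(Cc4ccccc4)n[nH]c3cc2O)cc1`, takes the same route as compounds 2 and 3. The change from compound 1 is 4-ethylbenzyl in place of furan-2-yl on an amide-type nitrogen.

Both measured steps that bear on this change replace furan-2-yl with a substituted benzyl, and they point in opposite directions: one lowers the number within the scatter, the other raises it modestly beyond it. A third benzyl variant is therefore expected to land somewhere in the band spanned by compounds 2 and 3, with no confident direction from compound 1. The estimated step is a 1.4-fold higher number from compound 1 to compound 4 (0.15 log units; within the scatter), at most a modest change. Compound 4 is expected to give about 3500 nM in this assay, within 1200 nM to 10000 nM.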

Compound 4, half-maximal inhibitory concentration: 9400 nM
For compound 4 the middle estimate is 2.7-fold (0.43 log units) below the measured one; the range from low to high includes it.
By their numbers in this assay, from the lowest: compounds 2 and 1 (each within the scatter of the next); then compounds 3 and 4 (each within the scatter of the next).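

With compound 4, two of the three benzyl groups on the amide-type nitrogen now give numbers beyond the scatter on the higher side of the furan-2-yl compound in this assay (a 3.8-fold higher number from compound 1 to compound 4 (0.58 log units; beyond the scatter)), and the 2-fluorobenzyl group of compound 2 is the one that goes against this. The 4-ethylbenzyl and 3-bromobenzyl groups cannot be told apart in this read-out (a 1.3-fold higher number from compound 3 to compound 4 (0.12 log units; within the scatter)), even though they carry different substituents, whereas the step from the 2-fluorobenzyl group is the largest among the benzyl groups shown (a 6.3-fold higher number from compound 2 to compound 4 (0.80 log units; beyond the scatter)). The position therefore responds to the choice of benzyl group only modestly, and among these groups only compound 2 stays within the scatter of compound 1.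

Nothing available here accounts for why compound 2 separates from compounds 3 and 4. On these data alone, it remains open whether an unsubstituted benzyl group, or a benzyl group carrying an amine or a carboxylic acid, would fall with compound 2 or with compounds 3 and 4.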